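Swapping the amide for a small sulfonamide on the core

This account rests on a few compounds, and the source may have more. Where it says the series, first, only, none or still open, it means among the compounds named here.

Measured compounds in a functional assay (aorta) for antagonist activity, with Oryctolagus cuniculus as the target; a higher number here means a weaker inhibitor, a lower number a stronger inhibitor:
- compound 1 `CCCCc1ccc(CN(Cc2ccccc2)C(C)=O)c(=O)n1Cc1ccc(-c2ccccc2-c2nn[nH]n2)cc1` gives 1 nM
- compound 2 `CCCCc1ccc(CN(Cc2ccccc2)S(=O)(=O)c2ccc(C)cc2)c(=O)n1Cc1ccc(-c2ccccc2-c2nn[nH]n2)cc1` gives 60 nM
- compound 3 `CCCCc1ccc(CN(Cc2ccccc2)S(=O)(=O)c2ccccc2)c(=O)n1Cc1ccc(-c2ccccc2-c2nn[nH]n2)cc1` gives 20 nM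

Compound 1 has the lowest number of the three, so it is the strongest inhibitor here; its steps to both others lie beyond the scatter. The untested compound 4 `CCCCc1ccc(CN(C)S(C)(=O)=O)c(=O)n1Cc1ccc(-c2ccccc2-c2nn[nH]n2)cc1` differs from compound 1 in one place: methyl(methylsulfonyl)amino in place of acetyl(benzyl)amino on a saturated chain carbon bound to an aromatic carbon.

Two measured steps speak to this change, both exchanging the acetyl for a sulfonyl group while the benzyl stays: a 60-fold higher number from compound 1 to compound 2 (1.78 log units; beyond the scatter) and a 20-fold higher number from compound 1 to compound 3 (1.30 log units; beyond the scatter). Both weaken inhibition strongly. Between the two sulfonyls, a 3.0-fold lower number from compound 2 to compound 3 (0.48 log units; beyond the scatter). Within the data shown here, no measured pair shows what happens when the benzyl is shrunk to methyl, so that part of the change is unsupported by data.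

Given that sulfonyl in place of acetyl cost compound 1 much potency, compound 4 is expected to be a clearly weaker inhibitor, with a 100-fold higher number from compound 1 to compound 4 (2.00 log units; beyond the scatter). The estimate for compound 4 in this assay is 100 nM, within a range from 20 nM to 600 nM.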

Compound 4, half-maximal inhibitory concentration: 0.2 nM
For compound 4 the middle estimate is 500-fold (2.70 log units) above the measured one, and the stated range ends above it.
By their numbers in this assay, from the lowest: compound 4; then compound 1; then compound 3; then compound 2.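

In this assay the step of a 5.0-fold lower number from compound 1 to compound 4 (0.70 log units; beyond the scatter) shows that a sulfonyl group on this nitrogen does not in itself weaken inhibition, even though the phenylsulfonyl step a 20-fold higher number from compound 1 to compound 3 (1.30 log units; beyond the scatter) pointed that way with the benzyl kept. This place also tolerates a much smaller group, since methyl(methylsulfonyl)amino enters where acetyl(benzyl)amino leaves, and compound 4 keeps strong inhibition without the six-membered aromatic ring of the benzyl. Nothing measured here explains this improvement.

Compound 4 replaces the benzyl and the acetyl together, so the compounds shown cannot tell which replacement carries the step, and the methyl amide or the benzyl methylsulfonamide would separate the two. Also open, from the compounds shown here alone, is how a longer chain such as propyl on this nitrogen, or a carboxylic acid at this place, would fare.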